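Compound 1 to compound 4: a side chain exchanged

This account rests on a few compounds, and the source may have more. Where it says the series, first, only, none or still open, it means among the compounds named here.

- compound 1 `CC(C)(O)CNCCCOc1ccc([C@H]2CC[C@]3(CC2)OOC2(O3)C3CC4CC(C3)CC2C4)cc1`: > 100 ug/mL
- compound 2 `CC(C)(O)CN1CCC(Oc2ccc([C@H]3CC[C@]4(CC3)OOC3(O4)C4CC5CC(C4)CC3C5)cc2)CC1`: 1.6 ug/mL
- compound 3 `c1cc([C@H]2CC[C@]3(CC2)OOC2(O3)C3CC4CC(C3)CC2C4)ccc1OC1CCNCC1`: > 100 ug/mL

In a physicochemical assay for solubility, read by nephelometry, measured as kinetic solubility, with a stated time of 30 min (a higher number here means a more soluble compound, a lower number a less soluble compound), compound 1 gives > 100 ug/mL, which is a limit of the assay and not a number. Compound 3 gives > 100 ug/mL, also a limit. On these data alone, compound 1 therefore stands at the limit of > 100 ug/mL in this assay, at which 2 of the 3 values shown sit, and its true value is unknown.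

Compound 4 `CS(=O)(=O)N1CCN(CCCOc2ccc([C@H]3CC[C@]4(CC3)OOC3(O4)C4CC5CC(C4)CC3C5)cc2)CC1` keeps the core of compound 1 and differs in one place: 4-(methylsulfonyl)piperazin-1-yl in place of (2-hydroxy-2-methylpropyl)amino on a saturated chain carbon, three bonds along the chain from an oxygen on an aromatic ring. Two measured steps offer guidance. The first, an at least 62-fold lower number from compound 1 to compound 2 (1.79 log units; beyond the scatter), replaces the same side chain with one that contains a ring. The second, an at least 62-fold higher number from compound 2 to compound 3 (1.79 log units; beyond the scatter), shows the number recovering when the substituent on the ring nitrogen is replaced by hydrogen. The step that the two limits leave unreadable from compound 1 to compound 3 cannot be sized. Compound 4 also gains a ring in its side chain, so a large fall is expected, guided by an at least 62-fold lower number from compound 1 to compound 2 (1.79 log units; beyond the scatter), though perhaps a smaller one. The estimated step is an at least 16-fold lower number from compound 1 to compound 4 (1.22 log units; beyond the scatter). For compound 4 the expected value is 6 ug/mL, with an estimated range of 1 ug/mL to 60 ug/mL.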

Compound 4, solubility: < 1.6 ug/mL
Compound 4 gave a limit, no number; the forecaster's own chance of this, stated with the estimate: 12%; middle value at least 3.7-fold (0.57 log units) from the limit.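

In this assay, with the propyl chain kept and only its end group exchanged, 4-(methylsulfonyl)piperazin-1-yl in place of (2-hydroxy-2-methylpropyl)amino gives an at least 62-fold lower number from compound 1 to compound 4 (1.79 log units; beyond the scatter), so a large fall at this place does not require giving up the open chain. Compound 4 stands at a limit of the assay, not at a number: the limit of < 1.6 ug/mL in this assay, at which 1 of the 4 values shown sits. Compound 2 and compound 4 both read low with a substituent on the ring nitrogen of the side chain, while compound 3, with hydrogen there, goes against any reading that the ring alone is enough.

The compounds shown do not separate the effect of the ring from that of the methylsulfonyl group, and a plain piperazin-1-yl or a morpholin-4-yl on the same chain would bear on this. The step from compound 1 to compound 3 cannot be read.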